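The compounds below may be only part of what the source reports. "The series", "measured", "known", "first", "only" and "open" are said of these compounds alone.

Working notes on the series, all read in a functional assay on SW-620 cells (Homo sapiens) for antiproliferative activity, read by sulforhodamine B assay, with a stated time of 48 h; a lower number here means a stronger inhibitor, a higher number a weaker inhibitor. Compound 1 (`O=C(CCCCCCN1C(=O)/C(=N\O)c2cc(F)ccc21)NO`) gives 110 nM and compound 2 (`Cc1ccc2c(c1)/C(=N/O)C(=O)N2CCCCCCC(=O)NO`) gives 990 nM in the same test. Compound 3 (`CO/N=C1/C(=O)N(CCCCCCC(=O)NO)c2ccc(F)cc21`) gives 1110 nM and so stands level, within the scatter, with compound 2 and well over the number of compound 1. The next entry is compound 4 (`CO/N=C1/C(=O)N(CCCCCCC(=O)NO)c2ccc(Br)cc21`), which carries bromo in place of fluoro on an aromatic carbon of compound 3: bromo in place of fluoro on an aromatic carbon. For the measured compounds named here, one measured step bears on this change, a 9.0-fold higher number from compound 1 to compound 2 (0.95 log units; beyond the scatter), where methyl in place of fluoro on an aromatic carbon moved the number upward. That step replaces the same fluoro group, but it starts from compound 1, which has a free oxime, whereas compound 3 has the methyl ether. Going by the values given here, no bromo compound has a measured value, so the step gives a direction and only a loose guide to size. The expected step in this assay is a 2.1-fold higher number from compound 3 to compound 4 (0.32 log units; beyond the scatter), upward and smaller than the one measured for methyl. For compound 4 2300 nM is the estimated value, with 700 nM to 6500 nM as the expected range.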

Compound 4, half-maximal inhibitory concentration: 2320 nM
Estimate against measurement, compound 4: 1.0-fold (0.00 log units) below; the measured number falls inside the stated range.
By their numbers in this assay, from the lowest: compound 1; then compounds 2 and 3 (each within the scatter of the next); then compound 4.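

In this assay the series now holds a step at this aromatic carbon with the methyl ether kept fixed: bromo in place of fluoro gives a 2.1-fold higher number from compound 3 to compound 4 (0.32 log units; beyond the scatter) and shows that a rise on replacing fluoro is not confined to the free oxime. Set beside a 9.0-fold higher number from compound 1 to compound 2 (0.95 log units; beyond the scatter) for methyl on the free oxime, it leaves fluoro with the lower number in both pairs that change this carbon, and neither pair goes against that reading. The two steps differ in the entering group as well as in the oxime form, so their sizes cannot separate one influence from the other, and the pattern extends no further than these four compounds.

The compounds shown leave open how chloro, a nitrile or an amine on this carbon would read, and whether bromo on the free oxime would move the number in the same direction. No supporting measurement bears on these groups, so the upward direction of the bromo step remains without an established explanation.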